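This account rests on a few compounds, and the source may have more. Where it says the series, first, only, none or still open, it means among the compounds named here.

Measured compounds, with their readings in a functional assay on HCT-116 cells (Homo sapiens) for antiproliferative activity, read by MTT assay, with a stated time of 72 h; a higher number here means a weaker inhibitor, a lower number a stronger inhibitor:
compound 1 `CC(C)(C)c1cn(C[C@H](O)[C@H]2OC(=O)C(OCc3ccccc3)=C2OCc2ccccc2)nn1`: 28300 nM
compound 2 `Cc1ccc(S(=O)(=O)NCc2cn(C[C@H](O)[C@H]3OC(=O)C(OCc4ccccc4)=C3OCc3ccccc3)nn2)cc1`: 13100 nM
compound 3 `O=C1O[C@H]([C@@H](O)Cn2cc(-c3cccc(O)c3)nn2)C(OCc2ccccc2)=C1OCc1ccccc1`: 42900 nM

Compound 1 holds the second highest number of the three in this assay; its nearest neighbour is compound 3, a gap within the scatter, while compound 2 is the furthest, giving the lower number a 2.2-fold lower number from compound 1 to compound 2 (0.33 log units; beyond the scatter).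

Compound 4 `O=C1O[C@H]([C@@H](O)Cn2cc(-c3cc(F)cc(F)c3)nn2)C(OCc2ccccc2)=C1OCc1ccccc1` differs from compound 1 by 3,5-difluorophenyl in place of tert-butyl on an aromatic carbon. The step that bears on it is the other swap of tert-butyl for an aryl group, a 1.5-fold higher number from compound 1 to compound 3 (0.18 log units; within the scatter), which stayed within the scatter. The steps of a 2.2-fold lower number from compound 1 to compound 2 (0.33 log units; beyond the scatter) and a 3.3-fold higher number from compound 2 to compound 3 (0.52 log units; beyond the scatter) concern a different group and inform only indirectly. For compound 4 in this assay a step of a 1.2-fold higher number from compound 1 to compound 4 (0.09 log units; within the scatter) is therefore expected, no more than the scatter. Compound 4 is estimated at 35000 nM, ranging from 15000 nM to 80000 nM.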

Compound 4, half-maximal inhibitory concentration: 48200 nM
Compound 4: middle estimate off by 1.4-fold (0.14 log units), on the low side; the measured number falls inside the stated range.
By their numbers in this assay, from the lowest: compound 2; then compounds 1, 3 and 4 (each within the scatter of the next).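

In this assay 3,5-difluorophenyl on this aromatic carbon reads level with tert-butyl (a 1.7-fold higher number from compound 1 to compound 4 (0.23 log units; within the scatter)) and with 3-hydroxyphenyl (a 1.1-fold higher number from compound 3 to compound 4 (0.05 log units; within the scatter)), so a second aryl group again leaves the reading within the scatter, now with fluorine in place of the hydroxyl-bearing ring. Only (((4-methylphenyl)sulfonyl)amino)methyl stands apart, and modestly (a 3.7-fold higher number from compound 2 to compound 4 (0.57 log units; beyond the scatter)). No measured evidence bears on these readings.

Open: how an amine or a carboxylic acid on this carbon would read, and whether a simple aminomethyl chain without the sulfonyl and tolyl parts would keep the lower number of compound 2.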